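Fluoro for methyl on the carboxamide ring

The source may hold more compounds than are shown below. What is called first, only, known or untested is meant among the compounds shown, and "the series" means these compounds.

Compound 1 `Cc1cc(-c2sc(Cc3cccc(C(F)(F)F)c3)nc2C)ccc1C(N)=O` and compound 2 `Cc1cc(C(N)=O)ccc1-c1sc(Cc2cccc(C(F)(F)F)c2)nc1C` share a core and differ only in where the methyl and the carbamoyl group sit on the ring bearing the amide. In a functional assay on cells for agonist activity at G-protein coupled receptor 52 (Homo sapiens), read by AlphaScreen and cAMP accumulation, with a stated time of 30 min (on this read-out higher numbers stand for larger maximal responses and lower numbers for smaller maximal responses), compound 1 gives 86% and compound 2 gives 87%. The two values lie within the scatter of each other, so compound 1 stands lowest of the two numbers only in a formal sense; nothing separates it from compound 2.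

Compound 3 `Cc1nc(Cc2cccc(C(F)(F)F)c2)sc1-c1ccc(C(N)=O)c(F)c1` has not yet been measured in this assay. Relative to compound 1 the change is fluoro in place of methyl on an aromatic carbon. No step between two measured compounds covers this exchange, so the expectation can rest only on the two numbers shown, which suggest the maximal response in this series sits near the top of the scale and is not easily shifted. The step from compound 1 to compound 3 is expected to be a number 2 percentage points lower from compound 1 to compound 3 (within the scatter), that is, none beyond the scatter in either direction. Compound 3 is therefore estimated at 84%, with a range from 65% to 100%.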

Compound 3, largest response reached (Emax), in percent of the reference or control that the assay uses: 84%
The estimate for compound 3 equals the measured number at the digits printed, within the range that was stated.
By their numbers in this assay, from the lowest: compounds 3, 1 and 2 (each within the scatter of the next).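

In this assay, fluoro in place of methyl on an aromatic carbon, ortho to a carbamoyl group and meta to a large group, gives a number 2 percentage points lower from compound 1 to compound 3 (within the scatter). This carbon therefore accepts a second kind of substituent with no separable effect on the maximal response, whereas the earlier pair showed only that methyl and carbamoyl can exchange places on the ring bearing the amide. The data offer no measurement that explains this result, so the finding remains a description of maximal response for this single exchange.

The compounds shown leave open whether a chloro, methoxy or nitrile group on this carbon would also leave the maximal response within the scatter of the values seen so far, and whether a longer chain such as ethyl would do the same. They also leave open whether a carboxylic acid or a primary amine in place of the carbamoyl group would keep the response in this range, and whether fluoro would behave the same way in the arrangement of compound 2.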